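The source may report more compounds than this note shows. Statements on the series, on what has been measured and on what is new or still open speak of the compounds shown alone.

Series around the shared core of compound 1 `Cc1ccc(Oc2ccc(C(=O)N3CCOC3=O)cc2)cc1`, a cyclic carbamate carrying an aroyl group, tested in an assay on HEK293 cells for inhibition of N-acylethanolamine-hydrolyzing acid amidase (Rattus norvegicus), read by LC-MS, with a stated time of 30 min; a higher number here means a weaker inhibitor, a lower number a stronger inhibitor. In this assay compound 1 gives 6400 nM. Going by the values given here, compound 2 `CCCCCCOc1ccc(C(=O)N2CCOC2=O)cc1` gives 640 nM in this assay; of the two numbers recorded so far it is the lower one, with compound 1 the only neighbour. Among the compounds with values here, the one step between measured compounds is a 10-fold lower number from compound 1 to compound 2 (1.00 log units; beyond the scatter).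

Compound 3 `O=C1OCCN1C(=O)c1ccc(OC2CCC(O)CC2)cc1` is not yet measured. Its change from compound 2: 4-hydroxycyclohexyl in place of hexyl on an oxygen on an aromatic ring. Within the data shown here, no measured step involves a saturated ring or a hydroxyl at this position; the only step that bears on the site, a 10-fold lower number from compound 1 to compound 2 (1.00 log units; beyond the scatter), shows that the group on this oxygen can move the number well beyond the scatter. A somewhat higher number is expected, with wide uncertainty, and the expected step is a 2.3-fold higher number from compound 2 to compound 3 (0.37 log units; beyond the scatter). For compound 3 the estimate in this assay is 1500 nM, within 400 nM to 6000 nM.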

Compound 3, half-maximal inhibitory concentration: 210 nM
Beside the measured number, compound 3's estimate is 7.1-fold (0.85 log units) above it; the measured number lies below the stated range.
By their numbers in this assay, from the lowest: compound 3; then compound 2; then compound 1.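

In this assay, replacing hexyl with 4-hydroxycyclohexyl on this oxygen gives a 3.0-fold lower number from compound 2 to compound 3 (0.48 log units; beyond the scatter), so a six-membered carbon ring carrying a hydroxyl is tolerated here and goes beyond what the open chain reached. Against the aromatic group the change is larger, with a 30-fold lower number from compound 1 to compound 3 (1.48 log units; beyond the scatter), and compound 3 now holds the lowest number of the three. No supporting data bear on why these numbers move.

The ring and the hydroxyl enter together, so the compounds shown do not tell which of them carries the step. An unsubstituted cyclohexyl would separate the two, and an amine or a methoxy in place of the hydroxyl would test whether that group matters at all.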